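A few compounds are considered here, and "the series" means these few. Any claim that something is new, unique, unknown or untested is made for them only; others in the source may bear on it.

Compound 3 `CC/C(=C(/c1ccc(/C=C/C(=O)O)cc1)c1cnc2[nH]ncc2c1)c1ccccc1` stands highest of the three numbers in a functional assay on MCF7 cells (Homo sapiens) for cytotoxicity, read by CellTiter-Glo, with a stated time of 5 days (on this read-out higher numbers stand for weaker inhibition and lower numbers for stronger inhibition), at 302 nM. Compound 1 `CC/C(=C(/c1ccc(/C=C/C(=O)O)cc1)c1ccc2[nH]ncc2c1)c1ccccc1` gives 7.2 nM, and compound 2 `CC/C(=C(/c1ccc(/C=C/C(=O)O)cc1)c1ccc2[nH]ncc2n1)c1ccccc1` gives 33 nM. The measured steps run a 4.6-fold higher number from compound 1 to compound 2 (0.66 log units; beyond the scatter), a 42-fold higher number from compound 1 to compound 3 (1.62 log units; beyond the scatter) and a 9.2-fold higher number from compound 2 to compound 3 (0.96 log units; beyond the scatter). Compound 4 `CC/C(=C(/c1ccc(/C=C/C(=O)O)cc1)c1cc2cn[nH]c2cc1C)c1ccccc1` differs from compound 3 by a group of 10 heavy atoms (8 carbon, 2 nitrogen; one five-membered aromatic ring with 2 hetero atoms, one six-membered aromatic ring of carbon only) in place of a group of 9 heavy atoms (6 carbon, 3 nitrogen; one five-membered aromatic ring with 2 hetero atoms, one six-membered aromatic ring with 1 hetero atom), on a double-bonded chain carbon bound to an aromatic carbon and a double-bonded chain carbon. This change brings back the six-membered ring of carbon only found in compound 1, with a methyl added, so the step of a 42-fold higher number from compound 1 to compound 3 (1.62 log units; beyond the scatter) bears on it in reverse. A large step toward a lower number in this assay is therefore expected, roughly a 30-fold lower number from compound 3 to compound 4 (1.48 log units; beyond the scatter). For the measured compounds named here, compound 4 is estimated at 10 nM in this assay, with a range from 3 nM to 40 nM, since the added methyl has no measured precedent here.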

Compound 4, half-maximal inhibitory concentration: 468 nM
Compound 4: middle estimate off by 47-fold (1.67 log units), on the low side; measured number above the stated range.
By their numbers in this assay, from the lowest: compound 1; then compound 2; then compounds 3 and 4 (each within the scatter of the next).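

Methyl in place of hydrogen on an aromatic carbon is a large step in this assay, giving a 65-fold higher number from compound 1 to compound 4 (1.81 log units; beyond the scatter), so a six-membered aromatic ring of carbon only does not by itself keep the low number of the core of compound 1. The 6-methyl-1H-indazol-5-yl group also gives a 14-fold higher number from compound 2 to compound 4 (1.15 log units; beyond the scatter) and, within the scatter, a 1.5-fold higher number from compound 3 to compound 4 (0.19 log units; within the scatter). No available evidence bears on the reason for these steps. On these data alone, whether a fluorine atom or a methoxy group on that aromatic carbon would give a step of similar size remains open.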